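The source may report more compounds than this note shows. Statements on the series, on what has been measured and on what is new or still open speak of the compounds shown alone.

In a functional assay on HT-29 cells (Homo sapiens) for cytotoxicity, read by MTT assay, with a stated time of 96 h (on this read-out higher numbers stand for weaker inhibition and lower numbers for stronger inhibition), compound 1 `COC1=C[C@]23C(=CC1=O)CCN(C(=O)C(F)(F)F)C2CCc1cc(OC)c(OC)c(OC)c13` has the entry "not determined" (no result reported), so it offers no number for comparison. For the measured compounds named here, that leaves compound 2 `COc1cc2c(cc1O)[C@@H]1CCc3cc(OC)c(OC)c(OC)c3[C@H]2CN1S(C)(=O)=O`, at 11600 nM, as the only measured value, and a lone value cannot yet be ranked against any other compound. Compound 3 `COc1cc2c(cc1O)[C@@H]1CCc3cc(OC)c(OC)c(OC)c3[C@H]2CN1S(=O)(=O)c1ccc(C)cc1` keeps the core of compound 2 and alters one group: 4-methylphenyl in place of methyl on a sulfonyl sulfur, with 4-methylphenyl in place of methyl on a sulfonyl sulfur. Going by the values given here, no measured pair shows what this swap does in this assay, so any forecast must stay cautious. A modest gain in inhibition, meaning a lower number, is expected, although a result within the usual scatter would be no surprise. The expected change is a 1.9-fold lower number from compound 2 to compound 3 (0.29 log units; within the scatter). For compound 3 the estimated value is 6000 nM, with an expected range of 1500 nM to 25000 nM.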

Compound 3, half-maximal inhibitory concentration: 10800 nM
Estimate against measurement, compound 3: 1.8-fold (0.26 log units) below; measured number inside the range.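

In this assay, for the compounds shown here, the first measured pair at this position gives a 1.1-fold lower number from compound 2 to compound 3 (0.03 log units; within the scatter), so the change from methyl to 4-methylphenyl on a sulfonyl sulfur does not separate the two compounds. Adding a six-membered aromatic ring of carbon at this site therefore leaves the cytotoxicity read-out where it was, at least for this pair. No evidence is available to explain this result.

This single pair cannot show whether the same holds for other groups on the sulfonyl sulfur, such as a longer chain like butyl, or an aromatic ring that carries an amine or a carboxylic acid. It also leaves open whether changes elsewhere on the shared core would move the number more than this swap did.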